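The source may report more compounds than this note shows. Statements on the series, on what has been measured and on what is new or still open speak of the compounds shown alone.

The series shares one core in which a single group on one aromatic carbon is varied. Compound 1 `O=C(Nc1cccc(C(=O)O)c1)N[C@H]1CC[C@H](Oc2ccc(F)cc2)CC1` carries a carboxy there. In a functional assay on CRL2813 cells (Homo sapiens) for cytotoxicity, read by sulforhodamine B assay, with a stated time of 5 days (a higher number here means a weaker inhibitor, a lower number a stronger inhibitor), compound 1 gives only a limit, > 20000 nM (the limit of > 20000 nM in this assay, at which 1 of the 3 values shown sits). Compound 2 `O=C(Nc1cccc([N+](=O)[O-])c1)N[C@H]1CC[C@H](Oc2ccc(F)cc2)CC1` carries a nitro and gives 6700 nM; compound 3 `CSc1cccc(NC(=O)N[C@H]2CC[C@H](Oc3ccc(F)cc3)CC2)c1` carries a methylsulfanyl and gives 11100 nM. Of the two numbers shown, compound 3 has the highest, with compound 2 nearest; the gap a 1.7-fold higher number from compound 2 to compound 3 (0.22 log units; within the scatter) is within the scatter, so no order between the two can be stated. The third value is the limit of compound 1. Among the measured steps, an at least 2.9-fold lower number from compound 1 to compound 2 (0.47 log units; beyond the scatter) is the only one beyond the scatter, while an at least 1.8-fold lower number from compound 1 to compound 3 (0.25 log units; that floor lies within the scatter) has a floor within the scatter.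

Compound 4 `COC(=O)c1cccc(NC(=O)N[C@H]2CC[C@H](Oc3ccc(F)cc3)CC2)c1` differs from compound 3 in one place: methoxycarbonyl in place of methylsulfanyl on an aromatic carbon. Going by the values given here, no measured step exchanges these two groups, and none reaches a methoxycarbonyl; the swaps at this carbon between carboxy, nitro and methylsulfanyl moved the numbers by at most a modest step, and only compound 1 with its carboxy sat at the limit. The step to compound 4 is therefore expected to stay within the scatter or run slightly upward, a 1.1-fold lower number from compound 3 to compound 4 (0.05 log units; within the scatter). For compound 4 the estimate in this assay is 10000 nM, with a range of 4000 nM to 25000 nM.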

Compound 4, half-maximal inhibitory concentration: 9200 nM
Compound 4: middle estimate off by 1.1-fold (0.04 log units), on the high side, and the stated range covers the measured number.
By their numbers in this assay, from the lowest: compounds 2, 4 and 3 (each within the scatter of the next). At a limit, above all of these: compound 1.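

In this assay, methoxycarbonyl at this aromatic carbon cannot be told apart from either methylsulfanyl (a 1.2-fold lower number from compound 3 to compound 4 (0.08 log units; within the scatter)) or nitro (a 1.4-fold higher number from compound 2 to compound 4 (0.14 log units; within the scatter)), so compounds 2, 3 and 4 now form a group of three with no order among them, despite the different groups they carry. The new comparison is the one with the carboxy: a methyl in place of the hydrogen on the oxygen next to a carbonyl group is a single small change, and it gives a step beyond the scatter (an at least 2.1-fold lower number from compound 1 to compound 4 (0.33 log units; beyond the scatter)), which shows that a carbonyl at this carbon can sit with the numbers of compounds 2 and 3 and that the separation of compound 1 follows the free carboxy rather than the carbonyl alone. Compound 1 stands at a limit, so that step is a floor and gives no size: the limit of > 20000 nM in this assay, at which 1 of the 4 values shown sits.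

On these data alone, whether the separation belongs to carboxylic acids in particular stays open, since a primary amide, an amine or a sulfonic acid at the same carbon would test it. The compounds shown also leave open whether a hydrogen at this carbon, or a longer ester chain such as ethoxycarbonyl, stays with compounds 2, 3 and 4.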